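The source may hold more compounds than are shown below. What is called first, only, known or untested is meant among the compounds shown, and "the series" means these compounds.

In a toxicity assay on Huh-7.5 cells (Homo sapiens) for cytotoxicity, read by MTT assay, with a stated time of 96 h (on this read-out lower numbers stand for higher toxicity in this test and higher numbers for lower toxicity in this test), compound 1 `CN(C)CCN(C)c1ccc(C#N)c(CN2CCN(C(c3ccccc3)c3ccc(Cl)cc3)CC2)c1` gives 5660 nM and compound 2 `CN(C)CCN(C)c1ccc(C#N)c(CN2CCN([C@@H](c3ccccc3)c3ccc(Cl)cc3)CC2)c1` gives 8780 nM within the scatter of each other. Going by the values given here, compound 3 `CNCCN(C)CCN(C)c1ccc(C#N)c(CN2CCN(C(c3ccccc3)c3ccc(Cl)cc3)CC2)c1` carries (methylamino)methyl in place of hydrogen on a saturated chain carbon bound to an amine nitrogen as its only difference from compound 1, so the dimethylamino end becomes methyl(2-(methylamino)ethyl)amino. Among the compounds with values here, the one measured step runs a 1.6-fold higher number from compound 1 to compound 2 (0.19 log units; within the scatter) and concerns drawn configuration only, leaving the chain untouched, so it sets no size for this change. No step beyond the scatter is therefore expected in this assay for this change, the estimated step being a 1.1-fold lower number from compound 1 to compound 3 (0.05 log units; within the scatter) with no firm direction. Compound 3 is expected at 5000 nM within an estimated range of 2000 nM to 13000 nM in this read-out.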

Compound 3, half-maximal cytotoxic concentration: 4710 nM
For compound 3 the middle estimate is 1.1-fold (0.03 log units) above the measured one, and the stated range covers the measured number.
By their numbers in this assay, from the lowest: compounds 3, 1 and 2 (each within the scatter of the next).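

In this assay this position now has a measured step, a 1.2-fold lower number from compound 1 to compound 3 (0.08 log units; within the scatter) for methyl to 2-(methylamino)ethyl. Placing (methylamino)methyl on a saturated chain carbon bound to an amine nitrogen, with its hydrogen-bond donor and acceptor, thus leaves the number within the scatter for this pair. Nothing on record bears on this step or gives a cause for it.

Going by these compounds, whether a primary amine, a carboxylic acid or a longer chain at this chain end would give a step beyond the scatter remains open. A single pair also cannot show a trend with chain length.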